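This account rests on a few compounds, and the source may have more. Where it says the series, first, only, none or still open, it means among the compounds named here.

Measured so far in a physicochemical assay for lipophilicity, read by HPLC, at pH 7.5; on this read-out lower numbers stand for lower lipophilicity and higher numbers for higher lipophilicity:
- compound 1 `N#Cc1c(-c2ccc(Br)cc2)nc2cnccc2c1NCC(N)=O`: 1.9
- compound 2 `CC[C@@H](Nc1c(C#N)c(-c2ccc(Br)cc2)nc2cnccc12)C(=O)O`: 1.6
- compound 3 `CC(C)(CC(N)=O)c1c(C#N)c(-c2ccc(Br)cc2)nc2cnccc12`: 2.1

Compound 3 reads 2.1. The measurements show a number 0.50 log units higher from compound 2 to compound 3 (beyond the scatter), so compound 2 is clearly separated from it. They also show a number 0.20 log units higher from compound 1 to compound 3 (within the scatter), so compound 1 cannot be told apart from it.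

The next compound is compound 4 `CC(Nc1c(C#N)c(-c2ccc(Br)cc2)nc2cnccc12)C(N)=O`. The change is a group of 6 heavy atoms (3 carbon, 2 nitrogen, 1 oxygen; no ring) in place of a group of 7 heavy atoms (5 carbon, 1 nitrogen, 1 oxygen; no ring), on an aromatic carbon. The entering group is (1-carbamoylethyl)amino, on the same aromatic carbon, ortho to a cyano group.

The closest guide is compound 1, which carries carbamoylmethyl on a nitrogen at that carbon and gives 1.9. Its step to the carbon-linked chain of compound 3 was small: a number 0.20 log units higher from compound 1 to compound 3 (within the scatter). Compound 2 also has a nitrogen at that carbon, but it carries 1-carboxypropyl, which ends in a different group. The measured a number 0.30 log units lower from compound 1 to compound 2 (within the scatter) is therefore a weaker guide. Going by the values given here, no measured step isolates the difference between carbamoylmethyl and 1-carbamoylethyl, so that part remains open.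

In this assay, no shift beyond the scatter is expected, and the expected step is a number 0.10 log units lower from compound 3 to compound 4 (within the scatter). The estimate for compound 4 is 2, with an expected range from 1.6 to 2.4.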

Compound 4, distribution coefficient: 2.1
Compound 4: middle estimate off by 0.10 log units, on the low side; the range from low to high includes it.
By their numbers in this assay, from the lowest: compounds 2, 1, 3 and 4 (each within the scatter of the next, the first and the last beyond it).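

In this assay, methyl in place of hydrogen on the saturated chain carbon bound to a carbonyl carbon and a nitrogen gives a number 0.20 log units higher from compound 1 to compound 4 (within the scatter), so this small addition to the chain does not produce a readable shift. Placing (1-carbamoylethyl)amino on the aromatic carbon ortho to a cyano group, in place of the carbon-linked chain, gives no change at the digits printed from compound 3 to compound 4 (within the scatter), which shows that at this position these two quite different attachments cannot be told apart. Going by these compounds alone, the only new step beyond the scatter is a number 0.50 log units higher from compound 2 to compound 4 (beyond the scatter), with 1-carbamoylethyl in place of 1-carboxypropyl on the nitrogen, but that swap alters the chain end and the chain length together, and compound 2 remains within the scatter of compound 1.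

Nothing available here offers an explanation for these readings. Still open, as far as these compounds go, is how a simple amine or a longer chain ending in the primary amide would read at this position, and whether the carboxylic acid or the extra chain carbon sets compound 2 apart from compound 4.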